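Dimethoxy to further methoxy on the carbonyl aryl

The source may hold more compounds than are shown below. What is called first, only, known or untested is meant among the compounds shown, and "the series" means these compounds.

Working notes on three measured members of the series and one still open. Compound 1 `COc1cc(-c2cc(/C=C/C(=O)c3ccc(N)cc3)[nH]n2)cc(OC)c1OC` gives, in a functional assay on A498 cells (Homo sapiens) for cytotoxicity, read by sulforhodamine B assay, with a stated time of 48 h, tested at 1 uM (a higher number here means a weaker effect of the compound at the concentration tested, a lower number a stronger effect), a value of 76%. Compound 2 `COc1ccc(-c2cc(/C=C/C(=O)c3cc(OC)c(OC)c(OC)c3)[nH]n2)cc1OC` gives in this assay a value of 65%. Compound 3 `COc1ccc(C(=O)/C=C/c2cc(-c3cc(OC)c(OC)c(OC)c3)n[nH]2)cc1OC` gives in this assay a value of 78%, the largest of the three numbers; compound 1 lies within the scatter of it, compound 2 lies beyond the scatter below it. Going by the values given here, the single one-place step measured so far, a number 2 percentage points higher from compound 1 to compound 3 (within the scatter), changes the aryl on the carbonyl carbon and leaves the read-out essentially unmoved.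

Compound 4 `COc1cc(C(=O)/C=C/c2cc(-c3cc(OC)c(OC)c(OC)c3)n[nH]2)cc(OC)c1OC` differs from compound 3 by methoxy in place of hydrogen on an aromatic carbon. Among the compounds with values here, no measured step covers this change; the step from compound 1 to compound 3 concerns another substituent on the same aryl and is within the scatter. Compound 2, which also carries three methoxy groups on the carbonyl aryl, differs from compound 3 in two places, so its lower value can only be noted, not assigned to this change. A modest move, if any, toward a lower number is therefore expected, with wide uncertainty: the estimated step is a number 6 percentage points lower from compound 3 to compound 4 (within the scatter). For compound 4 the estimate in this assay is 72%, within 58% to 86%.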

Compound 4, a percentage reported as activity, at one concentration (the size of the read-out at that concentration, not a potency): 80%
Beside the measured number, compound 4's estimate is 8 percentage points below it; the range from low to high includes it.
By their numbers in this assay, from the lowest: compound 2; then compounds 1, 3 and 4 (each within the scatter of the next).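

On the aryl on the carbonyl carbon, methoxy in place of hydrogen leaves the read-out in this assay essentially unmoved (a number 2 percentage points higher from compound 3 to compound 4 (within the scatter)), so a third methoxy group on that aryl brings no stronger effect at the concentration tested. The same exchange on the other aryl gives a move beyond the scatter (a number 15 percentage points higher from compound 2 to compound 4 (beyond the scatter)), toward a weaker effect, so across these two steps the outcome depends on which aryl receives the methoxy group, and the lower value of compound 2 now has a one-place comparison. No measurement at hand bears on why the two aryl rings respond differently to the same exchange, and the difference stands here as an observation only.

The compounds shown leave open whether any group other than methoxy at this place on the carbonyl aryl, such as a hydroxyl, an amine or a longer chain like ethoxy, would move the read-out beyond the scatter. They also leave open whether the flat response of compound 3 and compound 4 holds at other concentrations, since a single-concentration read-out gives no potency.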